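From Cyclobutyl to Methyl: Expecting Compound 3

A few compounds are considered here, and "the series" means these few. Any claim that something is new, unique, unknown or untested is made for them only; others in the source may bear on it.

Compound 1 `Cc1ccc(-c2nc(=O)o[nH]2)c(-c2ccc([C@@H](C)N(CC3CC3)c3nc(C(=O)NS(=O)(=O)C4CC4)c(C(C)C)s3)cc2)c1`: 2.4 h
Compound 2 `Cc1ccc(-c2nc(=O)o[nH]2)c(-c2ccc([C@@H](C)N(CC3CC3)c3nc(C(=O)NS(=O)(=O)C4CC4)c(C4CCC4)s3)cc2)c1`: 2.8 h

Of the compounds shown here, two have been measured in an ADME assay on the whole organism (Macaca fascicularis) for metabolic stability; a lower number here means that the compound disappears faster, a higher number that the compound lasts longer. Compound 1 gives 2.4 h, and compound 2 gives 2.8 h. Compound 2 holds the higher of the two numbers, but the gap to its nearest neighbour is small: a 1.2-fold higher number from compound 1 to compound 2 (0.07 log units; within the scatter), so the two cannot be told apart.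

Compound 3 `Cc1ccc(-c2nc(=O)o[nH]2)c(-c2ccc([C@@H](C)N(CC3CC3)c3nc(C(=O)NS(=O)(=O)C4CC4)c(C)s3)cc2)c1` differs from compound 2 in one place: methyl in place of cyclobutyl on an aromatic carbon. Going by the values given here, the only measured step that bears on this change is the exchange of one alkyl group for another at the same aromatic carbon, a 1.2-fold higher number from compound 1 to compound 2 (0.07 log units; within the scatter), and that step stayed within the scatter. Among the compounds with values here, no measured step reaches as far as the methyl group, so the data give no direction for this second shortening of the substituent. Within the data shown here, the single relevant step therefore supports no change beyond the scatter in this assay, and the expected step is a 1.1-fold lower number from compound 2 to compound 3 (0.03 log units; within the scatter). Compound 3 is accordingly estimated at 2.6 h, with a range from 1.3 h to 5.2 h.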

Compound 3, half-life: 2.1 h
Beside the measured number, compound 3's estimate is 1.2-fold (0.09 log units) above it, within the range that was stated.
By their numbers in this assay, from the lowest: compounds 3, 1 and 2 (each within the scatter of the next).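

With compound 3, the aromatic carbon next to the ring sulfur has now carried three alkyl groups in this assay, and the change reaches further than the earlier exchange of isopropyl for cyclobutyl. Replacing the cyclobutyl, a four-membered ring of 4 heavy atoms, with a methyl of 1 heavy atom gives a 1.3-fold lower number from compound 2 to compound 3 (0.12 log units; within the scatter) and replacing the isopropyl with methyl gives a 1.1-fold lower number from compound 1 to compound 3 (0.06 log units; within the scatter), so both steps stay within the scatter and the three compounds cannot be told apart by their half-lives, whether the group at this place is a ring, a branched group or a single carbon. Nothing at hand offers an explanation for this result.

The compounds shown leave open whether a group of another kind at this carbon, such as an amine, a carboxylic acid, a methoxy or a trifluoromethyl, or a longer chain such as n-butyl, would move the half-life beyond the scatter. They also leave open whether a plain hydrogen at this carbon would keep the half-life within the scatter of these three compounds.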